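Swapping the 4-carboxyphenyl group on the shared core

The source may hold more compounds than are shown below. What is called first, only, known or untested is meant among the compounds shown, and "the series" means these compounds.

Values in an ADME assay (liver) for metabolic stability, with Liver microsome (Homo sapiens) as the target, using microsomes; on this read-out lower numbers stand for a shorter-lived compound and higher numbers for a longer-lived compound:
- Compound 1 `CCc1nc2cc(Cl)ccn2c1C(=O)NCc1ccc(-c2ccc(C(=O)O)cc2)cc1`: > 2 h (a limit)
- Compound 2 `CCc1nc2cc(Cl)ccn2c1C(=O)NCc1ccc(N2CCCCC2)cc1`: 0.22 h
- Compound 3 `CCc1nc2cc(Cl)ccn2c1C(=O)NCc1ccc(N2CC3CCCCC3C2)cc1`: 0.248 h

Compound 1 gives only a limit and no number: the limit of > 2 h in this assay, at which 1 of the 3 values shown sits. Compound 4 `CCc1nc2cc(Cl)ccn2c1C(=O)NCc1ccc(-n2cc3c(c2)CCCC3)cc1` has not yet been measured, and its change from compound 1 is this: a group of 9 heavy atoms (8 carbon, 1 nitrogen; one five-membered aromatic ring with 1 hetero atom, one six-membered non-aromatic ring of carbon only) in place of a group of 9 heavy atoms (7 carbon, 2 oxygen; one six-membered aromatic ring of carbon only), on an aromatic carbon. The 4-carboxyphenyl group leaves, and a group with one five-membered aromatic ring with 1 hetero atom and one six-membered non-aromatic ring of carbon only enters.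

Two measured steps remove the same group. One shows an at least 9.0-fold lower number from compound 1 to compound 2 (0.95 log units; beyond the scatter), and the other shows an at least 8.0-fold lower number from compound 1 to compound 3 (0.90 log units; beyond the scatter). The two replacements themselves do not separate, with a 1.1-fold higher number from compound 2 to compound 3 (0.05 log units; within the scatter). The entering group of compound 3 is the nearest match, as it also holds a five-membered ring with a hetero atom and a six-membered carbon ring, although that five-membered ring is non-aromatic. Going by the values given here, no measured compound carries the aromatic version, so the transfer is uncertain.

A step of similar size toward a shorter half-life is therefore expected in this assay, guided by compound 3 at 0.248 h. The estimate amounts to an expected at least 7.4-fold lower number from compound 1 to compound 4 (0.86 log units; beyond the scatter). For compound 4 the expected half-life is 0.27 h, with an estimated range from 0.1 h to 0.8 h.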

Compound 4, half-life: 0.455 h
For compound 4 the middle estimate is 1.7-fold (0.23 log units) below the measured one; measured number inside the range.
By their numbers in this assay, from the lowest: compounds 2, 3 and 4 (each within the scatter of the next, the first and the last beyond it). At a limit, above all of these: compound 1.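

Compound 1 holds only a limit in this assay: the limit of > 2 h in this assay, at which 1 of the 4 values shown sits. Loss of the 4-carboxyphenyl group at this place, para to a large group, still gives an at least 4.3-fold lower number from compound 1 to compound 4 (0.64 log units; beyond the scatter), now with an aromatic five-membered ring in the entering group, so all three replacements shown fall clearly short of that limit. Setting the aromatic ring in place of its non-aromatic counterpart gives a 1.8-fold higher number from compound 3 to compound 4 (0.26 log units; within the scatter), so the two do not separate, whereas a 2.1-fold higher number from compound 2 to compound 4 (0.32 log units; beyond the scatter) makes this the first entering group shown that parts from piperidin-1-yl beyond the scatter, though only modestly.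

The compounds shown leave open whether the long half-life goes with the carboxylic acid or with the phenyl ring that carries it, and a plain phenyl group, or a piperidine bearing a carboxylic acid, would pull the two apart. On these data alone, how far the other compounds truly lie from compound 1 also stays open, as its entry is a limit and not a number.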